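This account rests on a few compounds, and the source may have more. Where it says the series, first, only, none or still open, it means among the compounds named here.

Measured in an ADME assay on MT2 cells (Homo sapiens) for cytotoxicity, read by XTT assay, with a stated time of 4 days; a lower number here means that less compound is tolerated, a higher number that more compound is tolerated:
- Compound 1 `Cc1cc(C#N)cc(C)c1Oc1ccc(N)c(Nc2ccc(C#N)cc2)n1`: > 100000 nM (a limit)
- Compound 2 `Cc1cc(/C=C/C(=O)O)cc(C)c1Oc1ccc([N+](=O)[O-])c(Nc2ccc(C#N)cc2)n1`: 34800 nM
- Compound 3 `Cc1cc(/C=C/C#N)cc(C)c1Oc1ccc([N+](=O)[O-])c(Nc2ccc(C#N)cc2)c1`: > 100000 nM (a limit)

Compound 1 stands at > 100000 nM, which is a limit of the assay and not a number. The set is marked by the limit of > 100000 nM in this assay, at which 2 of the 3 values shown sit. For the measured compounds named here, compound 2 gives 34800 nM, the only true number in the set.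

Compound 4 `Cc1cc(C#CC2CC2)cc(C)c1Oc1ccc(N)c(Nc2ccc(C#N)cc2)n1` keeps the core of compound 1 and carries 2-cyclopropylethynyl in place of cyano on an aromatic carbon, meta to two methyl groups: 2-cyclopropylethynyl in place of cyano on an aromatic carbon. Going by the values given here, no step between measured compounds is available to size this change.

In this assay a modest move towards less compound tolerated is expected, since compound 2 at 34800 nM shows that a number can be reached in this set. The expected size of the move is an at least 2.0-fold lower number from compound 1 to compound 4 (0.30 log units; that floor lies within the scatter). A reading at the limit remains a real possibility. For compound 4 the estimate is 50000 nM, with an expected range from 12000 nM to 100000 nM.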

Compound 4, half-maximal cytotoxic concentration: 5710 nM
The estimate for compound 4 lay 8.8-fold (0.94 log units) above the measured number, outside the stated range (below it).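

In this assay, for the compounds shown here, this aromatic carbon, meta to two methyl groups, is the first place where a single change can be sized: 2-cyclopropylethynyl in place of cyano gives an at least 17-fold lower number from compound 1 to compound 4 (1.24 log units; beyond the scatter). Compound 1 at > 100000 nM is a limit and not a number. The step is therefore a floor, and its full size stays unknown because the starting point sits at that limit: the limit of > 100000 nM in this assay, at which 2 of the 4 values shown sit.

Going by these compounds, whether the three-membered ring or simply the larger group goes with the lower number remains open, and a plain ethynyl group or a longer chain such as butynyl on the same carbon would separate the two. Going by these compounds alone, compound 2 and compound 3 differ from compound 4 in more than one place, so they give no second step at this position.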